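The source may report more compounds than this note shows. Statements on the series, on what has been measured and on what is new or still open speak of the compounds shown alone.

Among the compounds with values here, in a functional assay on IMR-32 cells (Homo sapiens) for cytotoxicity, read by sulforhodamine B assay, with a stated time of 48 h (a lower number here means a stronger inhibitor, a higher number a weaker inhibitor), compound 2 `C=CCOc1ccc(Br)cc1C(=O)c1cccnc1` reads 88000 nM, the highest of the three numbers so far. Compound 1 `O=C(c1cccnc1)c1ccccc1O` gives 33700 nM, and compound 3 `O=C(c1cccnc1)c1cc(Br)ccc1O` gives 23400 nM. The unmeasured compound 4 `C=CCOc1ccccc1C(=O)c1cccnc1` keeps the allyloxy group of compound 2 and loses the bromo: hydrogen in place of bromo on an aromatic carbon. Within the data shown here, two measured steps bear on this. The same exchange, read in the opposite direction, is known only on the free hydroxyl: a 1.4-fold lower number from compound 1 to compound 3 (0.16 log units; within the scatter). Among the measured compounds shown here, that is the closest precedent, and it is small. The other step, a 3.8-fold lower number from compound 2 to compound 3 (0.58 log units; beyond the scatter), concerns the allyl group rather than the bromo. It sets compound 2 apart from the hydroxyl compounds, a separation that compound 4 is expected to keep. For the measured compounds named here, no measured pair shows whether the bromo exchange behaves the same way when the allyloxy group is present. In this assay no step beyond the scatter is therefore expected, with a slightly higher number the likelier direction. The expected step is a 1.3-fold higher number from compound 2 to compound 4 (0.10 log units; within the scatter). The estimate for compound 4 is 110000 nM, with an expected range of 50000 nM to 220000 nM.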

Compound 4, half-maximal inhibitory concentration: 44000 nM
The estimate for compound 4 lay 2.5-fold (0.40 log units) above the measured number; measured number below the stated range.
By their numbers in this assay, from the lowest: compounds 3, 1, 4 and 2 (each within the scatter of the next, the first and the last beyond it).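

On the aromatic carbon para to an allyloxy group, the exchange of bromo for hydrogen can now be read with the allyloxy group present, and in this assay it stays within the scatter: a 2.0-fold lower number from compound 2 to compound 4 (0.30 log units; within the scatter). Set beside the same exchange on the free hydroxyl, this shows that the bromo step does not carry over unchanged from one core to the other: the same change on two cores in this assay, a 1.4-fold lower number (0.16 log units; within the scatter) from compound 1 to compound 3 and a 2.0-fold higher number (0.30 log units; within the scatter) from compound 4 to compound 2, 2.9-fold (0.46 log units) apart, beyond the scatter of two such steps. Within the data shown here, without the bromo, allyl in place of hydrogen on the oxygen also stays within the scatter, a 1.3-fold higher number from compound 1 to compound 4 (0.12 log units; within the scatter), so the separation of compound 2 from the hydroxyl compounds is not a property of the allyl group alone and is seen only with bromo and allyl together: the same change on two cores in this assay, a 3.8-fold lower number (0.58 log units; beyond the scatter) from compound 2 to compound 3 and a 1.3-fold lower number (0.12 log units; within the scatter) from compound 4 to compound 1, 2.9-fold (0.46 log units) apart, beyond the scatter of two such steps.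

From the compounds shown here alone, whether this dependence is particular to bromo, or would recur with chloro, methoxy or an amine on the same carbon, remains open. Also open, going by these compounds, is whether the allyl group itself matters on the oxygen, which a propyl group or a longer chain would test on both the bromo core and the core of compound 1.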